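The source may hold more compounds than are shown below. What is called first, only, known or untested is meant among the compounds shown, and "the series" means these compounds.

Measured in a functional assay on NCI-H1581 cells (Homo sapiens) for inhibition, read by MTT assay, with a stated time of 48 h, tested at 10 uM; on this read-out lower numbers stand for less inhibition and higher numbers for more inhibition at the one concentration tested (going by the name of the read-out):
compound 1 `CCc1ccc(Nc2cc(NC(=O)Nc3c(Cl)cccc3Cl)ncn2)cc1` gives 38.1%
compound 2 `COc1cc(Br)ccc1Nc1cc(NC(=O)Nc2c(Cl)cccc2Cl)ncn1` gives 47.3%
compound 3 `COc1ccc(F)cc1Nc1cc(NC(=O)Nc2c(Cl)cccc2Cl)ncn1` gives 73.1%

Compound 3 holds the highest number of the three; its steps to compound 2 and to compound 1 are both beyond the scatter, so it stands clearly above the other two.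

Compound 4 `Cc1ccc(Nc2cc(NC(=O)Nc3c(Cl)cccc3Cl)ncn2)cc1C` is compound 3 with 3,4-dimethylphenyl in place of 5-fluoro-2-methoxyphenyl on a nitrogen on an aromatic ring. Among the compounds with values here, two measured steps bear on this. The closer parallel is a number 35 percentage points higher from compound 1 to compound 3 (beyond the scatter), since compound 1, like compound 4, carries a phenyl bearing only alkyl groups and lacking methoxy and fluorine. The second is a number 25.8 percentage points higher from compound 2 to compound 3 (beyond the scatter), where the methoxy remains but the halogen changes. Read backwards, from compound 3 toward an alkyl-bearing phenyl, the first step points to a large drop. The 3,4-dimethylphenyl is not the 4-ethylphenyl of compound 1, so the size of the drop is uncertain, but a fall beyond the scatter is the expected outcome.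

The expected step is a number 31.1 percentage points lower from compound 3 to compound 4 (beyond the scatter). The estimate for compound 4 in this assay is 42%, with a range from 25% to 62%.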

Compound 4, a percentage reported as inhibition, at one concentration (the size of the read-out at that concentration, not a potency): 73.3%
Compound 4: middle estimate off by 31.3 percentage points, on the low side; measured number above the stated range.
By their numbers in this assay, from the lowest: compounds 1 and 2 (each within the scatter of the next); then compounds 3 and 4 (each within the scatter of the next).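

In this assay the piece now shows a number 0.2 percentage points higher from compound 3 to compound 4 (within the scatter), so at this place, on a nitrogen on an aromatic ring, a phenyl bearing only alkyl groups can match the number of compound 3 without methoxy or fluorine. Alkyl groups alone do not settle the number, as the series also shows a number 35.2 percentage points higher from compound 1 to compound 4 (beyond the scatter) and a number 26 percentage points higher from compound 2 to compound 4 (beyond the scatter); the alkyl-bearing pair of compounds 1 and 4 and the methoxy-bearing pair of compounds 2 and 3 each split into a lower and a higher member. No available evidence accounts for these differences.

Open, from the compounds shown here alone, is how a phenyl bearing a longer chain such as propyl, an amine or a carboxylic acid would compare with compounds 3 and 4. A single concentration also leaves open how compounds 3 and 4 compare in potency.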